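The compounds below may be only part of what the source reports. "The series", "measured", "known", "first", "only" and "open" are said of these compounds alone.

Two hydrazides built on the same core have so far been measured in an in vitro functional assay on 1321-N1 cells for antagonist activity at P2X purinoceptor 7 (Homo sapiens), read by FLIPR and calcium flux; on this read-out higher numbers stand for weaker inhibition and lower numbers for stronger inhibition. Compound 1 `Cc1ccccc1NNC(=O)CCC(C)C` carries a branched saturated chain on the carbonyl, and in this assay compound 1 gives 148 nM. Compound 2 `Cc1ccccc1NNC(=O)C1CCCCC1` carries a saturated ring directly on the carbonyl, and in this assay compound 2 gives 174 nM. Compound 1 has the lower of the two numbers, yet the gap to compound 2 lies within the usual scatter of repeated measurements, so the two compounds cannot be told apart on this read-out.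

Compound 3 `Cc1ccccc1NNC(=O)CC1CCCCC1` has not yet been measured. It differs from compound 1 in a single place: cyclohexyl in place of isobutyl on a saturated chain carbon bound to a carbonyl carbon. The carbonyl and the hydrazide linkage to the core are untouched; only the end of the chain changes. Within the data shown here, with just two measured compounds and no step between them that goes beyond the scatter, there is no basis for expecting a large shift in either direction. The step is therefore estimated as a 1.2-fold lower number from compound 1 to compound 3 (0.09 log units; within the scatter), a change not expected to exceed the scatter. For compound 3 the estimate is 120 nM, within a range from 50 nM to 300 nM.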

Compound 3, half-maximal inhibitory concentration: 38.9 nM
Compound 3: the middle estimate sits 3.1-fold (0.49 log units) above what was measured; measured number outside the range, below it.
By their numbers in this assay, from the lowest: compound 3; then compounds 1 and 2 (each within the scatter of the next).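

Among these compounds, at this position, on a saturated chain carbon bound to a carbonyl carbon, the end of the chain clearly matters: in this assay, cyclohexyl in place of isobutyl gives a 3.8-fold lower number from compound 1 to compound 3 (0.58 log units; beyond the scatter) and this is the first step that can be told apart from the scatter. The change is made of carbon alone, as an open branched end gives way to a six-membered ring, and neither group has a hydrogen-bond donor, a hydrogen-bond acceptor or a net charge. Nothing shown here bears on why the ring end gives the lower number.

Among the compounds shown here, the single step leaves open whether the ring itself matters or whether the larger number of carbons is enough, and a longer open chain or a cyclopentyl or phenyl group at the same place would help to separate those two readings. It also leaves open how the number would respond to an amine or a carboxylic acid on the end of the chain.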